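The source may hold more compounds than are shown below. What is called first, only, known or untested is meant among the compounds shown, and "the series" means these compounds.

Compound 1 `ClCc1cccc(Cn2cnc3c(Cl)ncnc32)c1`, in a functional assay on SK-MEL-28 cells (Homo sapiens) for cytotoxicity, read by sulforhodamine B assay, with a stated time of 48 h (a lower number here means a stronger inhibitor of growth, a higher number a weaker inhibitor of growth), compound 1 gives 5750 nM.
Compound 2 `ClCc1cccc(Cn2cnc3c(Cl)nc(Cl)nc32)c1`, in this assay compound 2 gives 5370 nM.
Compound 3 `ClCc1ccccc1Cn1cnc2ncnc(Cl)c21`, in this assay compound 3 gives 18600 nM.

Compounds 1 and 2 share one core, and the step between them is chloro in place of hydrogen on an aromatic carbon. It made a 1.1-fold lower number from compound 1 to compound 2 (0.03 log units; within the scatter), so the two values cannot be told apart by this assay. Compound 3 has the same atoms as compound 1 joined differently; the difference between the two cores is not broken down here. Compound 3 stands highest of the three numbers: compound 1 lies a good way lower, and compound 2 lower still, both gaps being beyond the scatter.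

Compound 4 `ClCc1ccccc1Cn1cnc2nc(Cl)nc(Cl)c21` has not been measured. It is made from compound 3 by chloro in place of hydrogen on an aromatic carbon, which is the same change that turned compound 1 into compound 2, at the same place on the ring. Since that change made a 1.1-fold lower number from compound 1 to compound 2 (0.03 log units; within the scatter), a step of about the same small size is expected here, and the expected step is a 1.1-fold lower number from compound 3 to compound 4 (0.04 log units; within the scatter). This rests on one measured pair only, so the range is kept wide. Compound 4 is thus estimated to give 17000 nM in this assay, with a likely span from 8000 nM to 36000 nM.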

Compound 4, concentration for total growth inhibition: > 100000 nM
Compound 4: no number, only a limit; the forecaster's own chance of this, stated with the estimate: 5%; at least 5.8-fold (0.76 log units) between middle value and limit.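

Compound 4 gives no number in this assay, only a limit of the assay, > 100000 nM. Chloro in place of hydrogen on an aromatic carbon thus gives an at least 5.3-fold higher number from compound 3 to compound 4 (0.73 log units; beyond the scatter), so the near-absent effect seen on the core of compound 1, where the same change gave a 1.1-fold lower number from compound 1 to compound 2 (0.03 log units; within the scatter), does not carry over to the core of compound 3: the same change on two cores in this assay, a 1.1-fold lower number (0.03 log units; within the scatter) from compound 1 to compound 2 and an at least 5.3-fold higher number (0.73 log units; beyond the scatter) from compound 3 to compound 4, at least 5.7-fold (0.76 log units) apart, beyond the scatter of two such steps. This shows that, for these two pairs, the outcome of the change depends on the core, so the result on one core could not be transferred to the other; it does not show which feature of the two cores matters, what the full size of the step on the core of compound 3 is, or how the change would behave on any further core.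

The compounds shown leave open whether an amine or a methoxy group, set on the same aromatic carbon between two ring nitrogen atoms, would follow chloro on either core. They also leave open whether the difference between the two cores would persist if the chloromethyl group gave way to a hydroxymethyl group or a longer chain.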